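Amide variation on a fluoroindanylidene acetamide series

The source may hold more compounds than are shown below. What is called first, only, known or untested is meant among the compounds shown, and "the series" means these compounds.

Measured so far:
compound 1, `O=C(/C=C1\CCc2ccc(F)cc21)NCCO` — 42%
compound 2, `O=C(/C=C1\CCc2ccc(F)cc21)N1CCCC1` — 10%

In a functional assay on the whole organism with Rattus norvegicus as the target, at a dose of 20 mg/kg by the oral route (on this read-out lower numbers stand for less inhibition and higher numbers for more inhibition at the one dose given (going by the name of the read-out)), compound 2 stands lowest of the two numbers; its nearest neighbour is compound 1, and the step of a number 32 percentage points lower from compound 1 to compound 2 (beyond the scatter) lies beyond the scatter. Compound 3, `CCN(C)C(=O)/C=C1\CCc2ccc(F)cc21`, is not yet measured. It differs from compound 2 by ethyl(methyl)amino in place of pyrrolidin-1-yl on a carbonyl carbon. Going by the values given here, no measured step exchanges one tertiary amide for another, so the step from compound 1 to compound 2 bears on it only loosely. No step beyond the scatter is expected in this assay, so the expected change is a number 3 percentage points higher from compound 2 to compound 3 (within the scatter). Compound 3 is estimated at 13%, between 0% and 30%.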

Compound 3, a percentage reported as inhibition, in the whole organism at one dose (the size of the read-out at that dose, not a potency): 20%
Estimate against measurement, compound 3: 7 percentage points below; the range from low to high includes it.
By their numbers in this assay, from the lowest: compounds 2 and 3 (each within the scatter of the next); then compound 1.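

In this assay, ethyl(methyl)amino in place of pyrrolidin-1-yl on the carbonyl carbon gives a number 10 percentage points higher from compound 2 to compound 3 (within the scatter), so the ring is not required for this level of inhibition. The step of a number 22 percentage points lower from compound 1 to compound 3 (beyond the scatter) shows that the gap to (2-hydroxyethyl)amino is not confined to the pyrrolidin-1-yl ring but also appears with an open-chain tertiary amide. No available evidence accounts for either step. The compounds shown leave open whether the higher number of compound 1 goes with its hydroxyl or with its amide hydrogen; ethylamino and (2-methoxyethyl)amino would separate the two.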